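A few compounds are considered here, and "the series" means these few. Any claim that something is new, unique, unknown or untested is made for them only; others in the source may bear on it.

Measured in a physicochemical assay for solubility, at pH 7; on this read-out lower numbers stand for lower solubility and higher numbers for higher solubility:

- Compound 1 `CN1CCC(C(=O)N2Cc3c(NC(=O)c4cccs4)n[nH]c3C2(C)C)CC1`: 155000 nM
- Compound 2 `CN1CCC(C(=O)N2Cc3c(NC(=O)c4ccco4)n[nH]c3C2(C)C)CC1`: > 225000 nM (a limit of the assay, not a number)
- Compound 3 `CN1CCC(C(=O)N2Cc3c(NC(=O)Nc4cccc(F)c4)n[nH]c3C2(C)C)CC1`: > 225000 nM (a limit of the assay, not a number)

Compound 3 has no exact value in this assay. It sits at the limit of > 225000 nM in this assay, at which 2 of the 3 values shown sit.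

The next compound, compound 4 `CN1CCC(C(=O)N2Cc3c(NC(=O)c4ccncc4)n[nH]c3C2(C)C)CC1`, carries pyridin-4-yl in place of (3-fluorophenyl)amino on a carbonyl carbon.

Pyridin-4-yl has not yet been measured at this place, but three measured steps change the same carbonyl carbon. The first two are an at least 1.4-fold higher number from compound 1 to compound 2 (0.16 log units; that floor lies within the scatter) and an at least 1.4-fold higher number from compound 1 to compound 3 (0.16 log units; that floor lies within the scatter). The third is a step that the two limits leave unreadable from compound 2 to compound 3. These steps therefore offer only two floors within the scatter and one unreadable step, and neither floor fixes a direction for the new change.

No step beyond the scatter is expected, and the estimate means a number no higher from compound 3 to compound 4 (the limit leaves the size open). Compound 4 is expected near 225000 nM, with an estimated range of 130000 nM to 350000 nM.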

Compound 4, solubility: > 225000 nM
Compound 4: a limit, no number; the forecaster's own chance of this, stated with the estimate: 60%; the middle value sits exactly at the limit.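

In this assay compound 4 gives > 225000 nM, which is a limit of the assay and not a number. For the compounds shown here, the only readable new step is an at least 1.4-fold higher number from compound 1 to compound 4 (0.16 log units; that floor lies within the scatter), so pyridin-4-yl, a six-membered aromatic ring with a hetero atom, gives no change from thiophen-2-yl that can be told from the scatter. The steps among compound 2, compound 3 and compound 4 cannot be read, and this carbonyl carbon now carries a third group that ends at the same limit: the limit of > 225000 nM in this assay, at which 3 of the 4 values shown sit.

As far as these compounds go, how compound 2, compound 3 and compound 4 rank against one another stays open, as none of them has an exact number. Also open, from the compounds shown here alone, is whether a simple phenyl, a longer alkyl chain or a carboxylic acid on this carbonyl carbon would stay at this limit or give a readable value.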